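The compounds below may be only part of what the source reports. "The series", "measured", "known", "first", "only" and "open" are said of these compounds alone.

The series is a set of three amides built on the shared core of compound 1 `N=C(N)c1cccc(C(=O)N[C@@H](C(=O)NCc2ccccc2)c2ccccc2)c1`. In an assay on isolated protein for binding affinity to serine protease 1 (Homo sapiens) (on this read-out higher numbers stand for weaker inhibition and lower numbers for stronger inhibition), compound 1 gives 5400 nM. Compound 2 `N=C(N)c1cccc(C(=O)NC(C(=O)NCC2CCC(CN)CC2)c2cccc3ccccc23)c1`, which carries a naphthalen-1-yl group and an aminomethyl-bearing cyclohexyl side chain, gives 2100 nM in this assay; that is the lowest of the two numbers recorded, and the gap to compound 1 lies beyond the usual scatter. Within the data shown here, no single-point step between compound 1 and compound 2 can be drawn, since the two differ in more than one place.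

Compound 3 `N=C(N)c1cccc(C(=O)NC(C(=O)NCC2CCC(CN)CC2)c2ccc(Cl)cc2)c1` differs from compound 2 in one place: 4-chlorophenyl in place of naphthalen-1-yl on a saturated chain carbon bound to an amide-type nitrogen and a carbonyl carbon. Among the measured compounds shown here, no measured pair shows what this exchange does in this assay, so the expectation rests on the neighbouring numbers alone. The step from compound 2 to compound 3 is expected to be small and, if anything, toward a higher number, close to the edge of the scatter, as a 1.5-fold higher number from compound 2 to compound 3 (0.18 log units; within the scatter). On that basis compound 3 is expected to give about 3200 nM in this assay, with a plausible range from 1100 nM to 9500 nM.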

Compound 3, inhibition constant: 6000 nM
Compound 3: middle estimate off by 1.9-fold (0.27 log units), on the low side; low and high end bracket the measured number.
By their numbers in this assay, from the lowest: compound 2; then compounds 1 and 3 (each within the scatter of the next).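

Among these compounds, with compound 3, the saturated chain carbon bound to an amide-type nitrogen and a carbonyl carbon gets its first reading in which only one place changes. In this assay, 4-chlorophenyl in place of naphthalen-1-yl gives a 2.9-fold higher number from compound 2 to compound 3 (0.46 log units; beyond the scatter), so with the aminomethyl-bearing cyclohexyl side chain held fixed, the group at this position moves the number modestly but beyond the scatter, toward weaker inhibition. Nothing at hand bears on why the number moves in this direction.

The single exchange removes one of the two aromatic rings and brings in a chlorine at once, so the compounds shown leave open how much of the step belongs to each change; a plain phenyl on the same aminomethyl-bearing cyclohexyl side chain would separate the two. Also open, on these data alone, is what the side chain contributes on its own, since compound 1 differs from both compound 2 and compound 3 in more than one place, and whether a naphthalen-2-yl group at this position would read like naphthalen-1-yl.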